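This account rests on a few compounds, and the source may have more. Where it says the series, first, only, none or still open, it means among the compounds named here.

Of the compounds shown here, three have been measured in a functional assay on A549 cells (Homo sapiens) for antiproliferative activity, read by MTT assay, with a stated time of 72 h; on this read-out higher numbers stand for weaker inhibition and lower numbers for stronger inhibition. Compound 1 `S=C(Sc1ccccc1)N1CCOCC1` gives 2520 nM, compound 2 `CC(C)(C)OC(=O)N1CCN(C(=S)Sc2ccc(C(C)(C)C)cc2)CC1` gives 769 nM, and compound 3 `CC(C)(C)OC(=O)N1CCN(C(=S)Sc2ccc(F)cc2)CC1` gives 1560 nM. Compound 3 thus holds the middle place of the three numbers, although its value lies within the usual scatter of the value for compound 1. The next compound, compound 4 `CC(C)(C)OC(=O)N1CCN(C(=S)Sc2cccc(Cl)c2)CC1`, carries 3-chlorophenyl in place of 4-fluorophenyl on a sulfur. Going by the values given here, only one measured step bears on this change: a 2.0-fold higher number from compound 2 to compound 3 (0.31 log units; beyond the scatter). Among the compounds with values here, that modest step involved a different exchange, and no measured compound carries a chloro group, so it suggests a scale but no direction. No step beyond the scatter is therefore expected in this assay. The estimated outcome is a 1.2-fold lower number from compound 3 to compound 4 (0.08 log units; within the scatter). For compound 4 the expected value is 1300 nM, with an estimated range from 650 nM to 2600 nM.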

Compound 4, half-maximal inhibitory concentration: 634 nM
Beside the measured number, compound 4's estimate is 2.1-fold (0.31 log units) above it; the whole stated range lies above it.
By their numbers in this assay, from the lowest: compounds 4 and 2 (each within the scatter of the next); then compounds 3 and 1 (each within the scatter of the next).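

In this assay the replacement of 4-fluorophenyl by 3-chlorophenyl on a sulfur gives a 2.5-fold lower number from compound 3 to compound 4 (0.39 log units; beyond the scatter) and so shows that this position responds to an exchange between two aryl groups of equal heavy-atom count. Going by these compounds alone, until now, the only step at this position was the exchange of tert-butyl for fluoro on the aromatic ring, with a 2.0-fold higher number from compound 2 to compound 3 (0.31 log units; beyond the scatter) as its result. Compound 2 at 769 nM and compound 4 at 634 nM stand within the scatter of each other, so a 3-chlorophenyl group matches the number of the tert-butyl compound. Nothing measured here accounts for the step.
From the compounds shown here alone, since both the halogen and its place differ between compound 3 and compound 4, their separate contributions remain open. Going by these compounds, a 4-chlorophenyl or 3-fluorophenyl group would separate them, and how a 3-aminophenyl group would fare also remains open.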